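Swapping Tert-Butyl for Dimethylamino on a Shared Core

The source may hold more compounds than are shown below. What is called first, only, known or untested is meant among the compounds shown, and "the series" means these compounds.

Compound 1, `C/C(=N\OCC(=O)O)c1ccc(C(C)(C)C)cc1`, was tested in a functional assay on the whole organism for inhibition, with Rattus norvegicus as the target, read by paw edema, with stated times of 1 h and 3 h, at a dose of 50 mg/kg by the oral route; a lower number here means less inhibition, a higher number more inhibition at the dose given (going by the name of the read-out). In this assay compound 1 gives < 20%, which is a limit of the assay and not a measured number. Two relatives share its core. Compound 2, `C/C(=N\OCC(=O)O)c1ccc(O)cc1`, carries a hydroxy in place of the tert-butyl on an aromatic carbon, and in this assay compound 2 gives < 20%, again a limit. Compound 3, `CC(=O)Nc1ccc(/C(C)=N/OCC(=O)O)cc1`, carries an acetamido on that aromatic carbon, and in this assay compound 3 gives < 20%, also a limit. The steps a step that the two limits leave unreadable from compound 1 to compound 2, a step that the two limits leave unreadable from compound 1 to compound 3 and a step that the two limits leave unreadable from compound 2 to compound 3 carry no readable size because of the limit of < 20% in this assay, at which 3 of the 3 values shown sit.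

Compound 4, `C/C(=N\OCC(=O)O)c1ccc(N(C)C)cc1`, is not yet measured. It differs from compound 1 by dimethylamino in place of tert-butyl on an aromatic carbon. Going by the values given here, none of the three measured steps has a readable size, so they give no direction for this change; they show only that three different groups on this aromatic carbon all leave the read-out at the limit. Compound 4 is therefore expected to sit at the limit as well, with an expected step that the limit leaves unreadable from compound 1 to compound 4. The estimate for compound 4 is 12%, within an expected range from 0% to 25%.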

Compound 4, a percentage reported as inhibition, in the whole organism at one dose (the size of the read-out at that dose, not a potency): < 20%
Compound 4 gave a limit, no number; the forecaster's own chance of this, stated with the estimate: 75%; the middle value does not contradict the limit.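

No step to compound 4 can be read from compound 1, compound 2 or compound 3, because all four compounds rest at the same assay limit: the limit of < 20% in this assay, at which 4 of the 4 values shown sit.

The compounds shown leave open how much paw edema inhibition each one actually gives, and whether any group at this aromatic carbon could reach a readable value.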